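The source may hold more compounds than are shown below. What is called first, only, known or untested is meant among the compounds shown, and "the series" means these compounds.

Measured so far in a functional assay on MCF7 cells (Homo sapiens) for inhibition, read by sulforhodamine B assay; a lower number here means a stronger inhibitor of growth, a higher number a weaker inhibitor of growth

- compound 1 `Fc1ccc(-c2ccc(-c3ccc(-c4nc5ccccc5[nH]4)cc3)cc2)cc1` gives 36200 nM
- compound 2 `Oc1ccc(-c2ccc(-c3ccc(-c4nc5ccccc5[nH]4)cc3)cc2)cc1` gives 30500 nM
- compound 3 `Clc1cccc(-c2ccc(-c3ccc(-c4nc5ccccc5[nH]4)cc3)cc2)c1` gives 36300 nM

Compound 3 cannot be separated from the other two compounds. The measured steps to it are a 1.0-fold higher number from compound 1 to compound 3 (0.00 log units; within the scatter) and a 1.2-fold higher number from compound 2 to compound 3 (0.08 log units; within the scatter), and neither exceeds the scatter.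

Next is compound 4 `COc1ccc(-c2ccc(-c3ccc(-c4nc5ccccc5[nH]4)cc3)cc2)cc1OC`, with 3,4-dimethoxyphenyl in place of 3-chlorophenyl on an aromatic carbon, para to a large group: 3,4-dimethoxyphenyl in place of 3-chlorophenyl on an aromatic carbon.

All three measured steps concern the same terminal aryl group. The third is a 1.2-fold lower number from compound 1 to compound 2 (0.07 log units; within the scatter), which is also within the scatter. Across compound 1, compound 2 and compound 3, this group has therefore been varied with no measurable effect on this assay, and none of the three goes against that reading. The evidence is thin, however, since none of these compounds carries a 3,4-dimethoxyphenyl group, and the data do not show how two substituents on this ring would behave. No shift in either direction is therefore expected beyond the scatter, although the range is kept somewhat wide.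

The estimated step is a 1.1-fold lower number from compound 3 to compound 4 (0.04 log units; within the scatter). For compound 4 the expected value is 33000 nM, with an estimated range from 16000 nM to 62000 nM.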

Compound 4, concentration for 50% growth inhibition: 7600 nM
Compound 4: the middle estimate sits 4.3-fold (0.64 log units) above what was measured; the measured number lies below the stated range.
By their numbers in this assay, from the lowest: compound 4; then compounds 2, 1 and 3 (each within the scatter of the next).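

In this assay the terminal aryl group is not a silent position after all: 3,4-dimethoxyphenyl separates from the other three groups, with a 4.8-fold lower number from compound 3 to compound 4 (0.68 log units; beyond the scatter), a 4.0-fold lower number from compound 2 to compound 4 (0.60 log units; beyond the scatter) and a 4.8-fold lower number from compound 1 to compound 4 (0.68 log units; beyond the scatter), whereas 3-chlorophenyl, 4-fluorophenyl and 4-hydroxyphenyl remain within the scatter of one another. Oxygen on this ring is not enough in itself among these compounds, since compound 2 with its 4-hydroxyphenyl group stays with compound 1 and compound 3, and only compound 4 carries two substituents or any methoxy group, so these two features cannot be told apart here. No measurement at hand accounts for the difference between 3,4-dimethoxyphenyl and the other three groups.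

As far as these compounds go, it remains open whether a single methoxy group at either of the two ring places would keep the lower number, or whether both are needed. Also open, from the compounds shown here alone, is how a longer chain such as ethoxy, an amine or a carboxylic acid on this ring would read, and whether any such group would take the series further than compound 4.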